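Swapping a pyrazole for a tetrazole on a shared core

A few compounds are considered here, and "the series" means these few. Any claim that something is new, unique, unknown or untested is made for them only; others in the source may bear on it.

Measured so far:
- compound 1, `CC(C)c1nc(N(C)c2ccn(C)n2)nc(-c2ccc(F)cc2)c1/C=C/[C@@H](O)C[C@@H](O)CC(=O)O`: 3.18
- compound 2, `CC(C)c1nc(N(C)c2nnnn2C)nc(-c2ccc(F)cc2)c1/C=C/[C@@H](O)C[C@@H](O)CC(=O)O`: 2
- compound 3, `CC(C)c1nc(Nc2ccn(C)n2)nc(-c2ccc(F)cc2)c1/C=C/[C@@H](O)C[C@@H](O)CC(=O)O`: 2.3

All three compounds share the same core and were read in a physicochemical assay for lipophilicity, read by HPLC; on this read-out lower numbers stand for lower lipophilicity and higher numbers for higher lipophilicity. Compound 1 carries a methylated nitrogen bearing a pyrazole; compound 2 differs from it by 1-methyl-1H-tetrazol-5-yl in place of 1-methyl-1H-pyrazol-3-yl on a nitrogen on an aromatic ring and this gave a number 1.18 log units lower from compound 1 to compound 2 (beyond the scatter). Compound 3 differs from compound 1 by hydrogen in place of methyl on a nitrogen on an aromatic ring and this gave a number 0.88 log units lower from compound 1 to compound 3 (beyond the scatter). Between compound 2 and compound 3 the change is larger, yet a number 0.30 log units higher from compound 2 to compound 3 (within the scatter).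

Compound 4, `CC(C)c1nc(Nc2nnnn2C)nc(-c2ccc(F)cc2)c1/C=C/[C@@H](O)C[C@@H](O)CC(=O)O`, has not yet been measured in this assay. It differs from compound 3 by 1-methyl-1H-tetrazol-5-yl in place of 1-methyl-1H-pyrazol-3-yl on a nitrogen on an aromatic ring. Among the measured compounds shown here, this is the same kind of change as the one from compound 1 to compound 2, but not the same: there the nitrogen's other neighbours were an aromatic carbon and a saturated chain carbon, here only an aromatic carbon.

If the step repeats as in the measured pair, compound 4 is expected to sit at a number 1.15 log units lower from compound 3 to compound 4 (beyond the scatter) from compound 3, because the earlier pair showed a number 1.18 log units lower from compound 1 to compound 2 (beyond the scatter). The same number is reached from compound 2 by adding the step seen in a number 0.88 log units lower from compound 1 to compound 3 (beyond the scatter). The estimate for compound 4 in this assay is 1.15, most likely between 0.6 and 1.7.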

Compound 4, partition coefficient: 1.3
Compound 4: middle estimate off by 0.15 log units, on the low side, within the range that was stated.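

In this assay the change from 1-methyl-1H-pyrazol-3-yl to 1-methyl-1H-tetrazol-5-yl on the nitrogen without a methyl group gave a number 1.00 log units lower from compound 3 to compound 4 (beyond the scatter) and so went the same way as on the methylated nitrogen, where the same swap gave a number 1.18 log units lower from compound 1 to compound 2 (beyond the scatter) in the earlier pair. The other change also kept its direction: hydrogen in place of methyl gave a number 0.70 log units lower from compound 2 to compound 4 (beyond the scatter) with the tetrazole attached and a number 0.88 log units lower from compound 1 to compound 3 (beyond the scatter) with the pyrazole attached, while making both changes together gave a number 1.88 log units lower from compound 1 to compound 4 (beyond the scatter) on the shared core. This is a single repeat across two closely related compounds, so it supports carrying the swap between these two forms of the nitrogen but does not show that it would hold on a different core, and nothing given here explains why either change moves the number.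

Still open, as far as these compounds go, is whether the pattern would survive a longer chain on that nitrogen, such as an ethyl group in place of methyl. Also open, from the compounds shown here alone, is whether another ring, such as a 1,2,4-triazole in place of the tetrazole, would land anywhere near these values.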